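Inverting the ring stereocentre of compound 2

A few compounds are considered here, and "the series" means these few. Any claim that something is new, unique, unknown or untested is made for them only; others in the source may bear on it.

Compound 1 `CN1C(=S)[C@H](NC(=O)c2n[nH]c(Cc3ccccc3)n2)COc2ccccc21` gives 22.6 nM; 76.3 nM (2 entries) in a functional assay on HT-29 cells (Homo sapiens) for inhibition, read by luminescence and CellTiter-Glo, with a stated time of 10 h (a higher number here means that more compound is needed for the effect, a lower number that less compound is needed), and serves as the reference point. Among the compounds with values here, compound 2 `O=C(N[C@H]1COc2ccccc2NC1=S)c1n[nH]c(Cc2ccccc2)n1` gives 736 nM in this assay as its only number, and one further entry holds no single number. Compound 3 `O=C(N[C@@H]1COc2ccccc2NC1=S)c1n[nH]c(Cc2ccccc2)n1` differs from compound 2 in this way: the two compounds have the same atoms and bonds and differ only in configuration as drawn: 1 of 1 stereo elements differ; a stereocentre at a saturated ring carbon is drawn S in compound 2 and R in compound 3. Within the data shown here, no measured step of this kind exists, so the direction is uncertain, but a shift well beyond the scatter towards less compound needed is expected. The expected change is a 4.9-fold lower number from compound 2 to compound 3 (0.69 log units; beyond the scatter) in this assay. For compound 3 the estimated value is 150 nM within an expected range of 20 nM to 3000 nM.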

Compound 3, half-maximal effective concentration: 8840 nM
Compound 3: the middle estimate sits 59-fold (1.77 log units) below what was measured; the measured number lies above the stated range.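

In this assay, the configuration at the saturated ring carbon matters strongly: a 12-fold higher number from compound 2 to compound 3 (1.08 log units; beyond the scatter), so the S form as drawn in compound 2 needs less compound than the R form in compound 3. The earlier compounds offered no comparison at this stereocentre, and this step can be assigned to it alone, as nothing else changes: the fact that compounds 2 and 3 differ only in the configuration as drawn

Still open, on these data alone, is whether the same preference for the S form holds in analogues of the shared core carrying a longer chain, such as an n-propyl group, or a carboxylic acid.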